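Compound 3 to compound 4: the amine substituent

The source may hold more compounds than are shown below. What is called first, only, known or untested is meant among the compounds shown, and "the series" means these compounds.

In a functional assay on HepG2 cells (Homo sapiens) for cytotoxicity, read by MTT assay, with a stated time of 48 h (on this read-out higher numbers stand for weaker inhibition and lower numbers for stronger inhibition), compound 1 `Cc1ccc(C(=O)N2N=C(c3cc4ccccc4oc3=O)CC2c2ccccc2)cc1` gives 52300 nM, compound 2 `CCC(=O)N1N=C(c2cc3ccccc3oc2=O)CC1c1ccccc1` gives 9610 nM and compound 3 `CCCNCC(=O)N1N=C(c2cc3ccccc3oc2=O)CC1c1ccccc1` gives 10800 nM. Compound 3 thus matches compound 2 within the scatter and lies clearly under compound 1. Compound 4 `CC(C)(C)NCC(=O)N1N=C(c2cc3ccccc3oc2=O)CC1c1ccccc1` carries tert-butyl in place of propyl on an amine nitrogen. Among the measured compounds shown here, no measured step changes the group on this nitrogen. The nearest evidence, a 1.1-fold higher number from compound 2 to compound 3 (0.05 log units; within the scatter), lies within the scatter. The steps of a 5.4-fold lower number from compound 1 to compound 2 (0.74 log units; beyond the scatter) and a 4.8-fold lower number from compound 1 to compound 3 (0.69 log units; beyond the scatter) are modest and beyond the scatter, but both replace 4-methylphenyl on a carbonyl carbon. No change beyond the scatter is therefore expected, the estimated step being a 1.1-fold lower number from compound 3 to compound 4 (0.03 log units; within the scatter). Compound 4 is estimated at 10000 nM, with an expected range of 5000 nM to 22000 nM.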

Compound 4, half-maximal inhibitory concentration: 31400 nM
The estimate for compound 4 lay 3.1-fold (0.50 log units) below the measured number; measured number above the stated range.
By their numbers in this assay, from the lowest: compounds 2 and 3 (each within the scatter of the next); then compounds 4 and 1 (each within the scatter of the next).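

Among the compounds shown here, at this amine nitrogen the group matters in this assay: tert-butyl in place of propyl gives a 2.9-fold higher number from compound 3 to compound 4 (0.46 log units; beyond the scatter) and is the first measured change here. Propylamino had left the number within the scatter of compound 2, whereas (tert-butyl)amino gives a 3.3-fold higher number from compound 2 to compound 4 (0.51 log units; beyond the scatter) and the wider replacement on the carbonyl carbon gives only a 1.7-fold lower number from compound 1 to compound 4 (0.22 log units; within the scatter) and stays within the scatter. Nothing measured on these compounds accounts for the step.

As far as these compounds go, whether a longer chain such as hexyl or a cyclic amine such as piperidine on this nitrogen tracks propyl or tert-butyl remains open.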